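Adding a Second Trifluoromethyl Group to a Urea Substituent

The source may report more compounds than this note shows. Statements on the series, on what has been measured and on what is new or still open speak of the compounds shown alone.

For the measured compounds named here, compound 1 `O=C(Nc1cccc(-n2cc(-c3ccncc3)c(-c3ccc(Cl)c(O)c3)n2)c1)Nc1cccc(C(F)(F)F)c1` was tested in a functional assay on A498 cells (Homo sapiens) for inhibition, read by sulforhodamine B assay, with a stated time of 48 h (on this read-out lower numbers stand for stronger inhibition of growth and higher numbers for weaker inhibition of growth), and gives 2240 nM, the highest of the three numbers measured so far. Two neighbours differ from it in one place each. Compound 2 `O=C(Nc1cccc(-n2cc(-c3ccncc3)c(-c3ccc(Cl)c(O)c3)n2)c1)Nc1ccc(Cl)c(Cl)c1` gives 940 nM, and the change from compound 1 to compound 2 is a 2.4-fold lower number from compound 1 to compound 2 (0.38 log units; beyond the scatter). Compound 3 `COc1cc(-c2nn(-c3cccc(NC(=O)Nc4cccc(C(F)(F)F)c4)c3)cc2-c2ccncc2)ccc1Cl` gives 958 nM, with a change from compound 1 to compound 3 of a 2.3-fold lower number from compound 1 to compound 3 (0.37 log units; beyond the scatter). Both steps lower the number, and both are modest.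

Compound 4 `O=C(Nc1cccc(-n2cc(-c3ccncc3)c(-c3ccc(Cl)c(O)c3)n2)c1)Nc1cc(C(F)(F)F)cc(C(F)(F)F)c1` has not been measured. The change from compound 1 to compound 4 is trifluoromethyl in place of hydrogen on an aromatic carbon. Going by the values given here, no measured step adds a trifluoromethyl group in this way, so the evidence is indirect. The step from compound 1 to compound 2 shows that altering the aryl group on the urea nitrogen changes the number in this assay only modestly, and the step to compound 3 shows the same scale for a change elsewhere. A modest lowering or a step within the scatter is therefore expected for compound 4.

Taking these two steps as a guide, compound 4 is expected to give about 1100 nM in this assay, with a plausible range from 450 nM to 2700 nM, which would be an estimated step of a 2.0-fold lower number from compound 1 to compound 4 (0.31 log units; beyond the scatter).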

Compound 4, concentration for 50% growth inhibition: 792 nM
Estimate against measurement, compound 4: 1.4-fold (0.14 log units) above; the range from low to high includes it.
By their numbers in this assay, from the lowest: compounds 4, 2 and 3 (each within the scatter of the next); then compound 1.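

Compounds 1 to 3 changed one aryl group for another or put a methyl on an oxygen, but none of them added a group to the urea's aryl ring while keeping what was already there. Trifluoromethyl in place of hydrogen on an aromatic carbon, meta to a trifluoromethyl group, gives a 2.8-fold lower number from compound 1 to compound 4 (0.45 log units; beyond the scatter) in this assay and so shows that this position accepts the four extra heavy atoms with a modest gain in growth inhibition, not a loss. Nothing measured here explains why the number falls.

Compound 4 and compound 2 differ only in the substituents on that ring and lie within the scatter of each other, so the two substitution patterns cannot be told apart in this assay. Going by these compounds, it remains open whether a different group at the same position, such as an amine or a carboxylic acid, would also be accepted, and whether the second trifluoromethyl group would lower the number in the same way on compound 3, which carries a methyl on the oxygen.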